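From methyl to chloro: an expected lipophilicity step

This account rests on a few compounds, and the source may have more. Where it says the series, first, only, none or still open, it means among the compounds named here.

Compound 1 `COc1cc(-c2cc(C(=O)O)c3ccccc3n2)ccc1OCC(=O)Nc1ccc(C)cc1` was measured in a physicochemical assay for lipophilicity, using the shake flask method, in phosphate buffer, measured as octanol-water partition, at pH 7.4 (on this read-out lower numbers stand for lower lipophilicity and higher numbers for higher lipophilicity), where compound 1 gives 1.2. Its one measured relative, compound 2 `COc1cc(-c2cc(C(=O)O)c3ccccc3n2)ccc1OCC(=O)Nc1ccc(F)cc1`, gives 1.1 in this assay; of the two numbers, compound 1's is the larger, but only by a number 0.10 log units lower from compound 1 to compound 2 (within the scatter), a gap within the scatter. Compound 3 `COc1cc(-c2cc(C(=O)O)c3ccccc3n2)ccc1OCC(=O)Nc1ccc(Cl)cc1` has not yet been measured. It differs from compound 1 in one place: chloro in place of methyl on an aromatic carbon. Going by the values given here, the single measured step that bears on this change is a number 0.10 log units lower from compound 1 to compound 2 (within the scatter), in which one small group replaced another at the same place and the number hardly moved. On that basis no step beyond the scatter is expected for compound 3, at most a slight rise, and the estimated step is a number 0.10 log units higher from compound 1 to compound 3 (within the scatter). Compound 3 is therefore expected to give 1.3 in this assay, with a range from 1 to 1.7.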

Compound 3, distribution coefficient: 1.5
Compound 3: middle estimate off by 0.20 log units, on the low side; low and high end bracket the measured number.
By their numbers in this assay, from the lowest: compounds 2, 1 and 3 (each within the scatter of the next, the first and the last beyond it).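

Chloro in place of fluoro gives a number 0.40 log units higher from compound 2 to compound 3 (beyond the scatter) in this assay, the first step beyond the scatter at this position, the aromatic carbon para to a large group. Chloro in place of methyl gives a number 0.30 log units higher from compound 1 to compound 3 (within the scatter), so this step, like the earlier one from methyl to fluoro, does not separate its two compounds, and only the fluoro and chloro pair stands apart. Nothing measured here gives a reason for the size of these steps.

The compounds shown carry only three small groups at this one position, so how an amine, a nitrile or a longer chain would read there remains open. On these data alone, whether these steps would hold on a core carrying an ester in place of its carboxylic acid is also open.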